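Swapping 4-methylphenyl for 2-chlorophenyl in compound 3

A few compounds are considered here, and "the series" means these few. Any claim that something is new, unique, unknown or untested is made for them only; others in the source may bear on it.

Measured in a functional assay on MCF7 cells (Homo sapiens) for antiproliferative activity, read by MTT assay, with a stated time of 48 h; on this read-out higher numbers stand for weaker inhibition and lower numbers for stronger inhibition:
compound 1 `N=C(N)N/N=C(/C=C/c1ccc(F)cc1)c1ccccc1`: 2500 nM
compound 2 `N=C(N)N/N=C(/C=C/c1ccc(Br)cc1)c1ccccc1`: 250 nM
compound 3 `Cc1ccc(/C=C/C(=N/NC(=N)N)c2ccccc2)cc1`: 16000 nM

Of these three, compound 3 has the highest number at 16000 nM and is the weakest inhibitor of the set, with its gaps to both others beyond the scatter. The next compound to be tested is compound 4 `N=C(N)N/N=C(/C=C/c1ccccc1Cl)c1ccccc1`, which differs from compound 3 in one place. The difference 2-chlorophenyl in place of 4-methylphenyl on a double-bonded chain carbon bound to a double-bonded chain carbon is 2-chlorophenyl in place of 4-methylphenyl on a double-bonded chain carbon bound to a double-bonded chain carbon.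

For the measured compounds named here, three measured steps bear on this change. Methyl in place of fluoro gave a 6.4-fold higher number from compound 1 to compound 3 (0.81 log units; beyond the scatter) and methyl in place of bromo gave a 64-fold higher number from compound 2 to compound 3 (1.81 log units; beyond the scatter) so both compounds with a halogen sit lower than the methyl compound. Bromo in place of fluoro gave a 10-fold lower number from compound 1 to compound 2 (1.00 log units; beyond the scatter) and this shows that the choice of halogen matters too. Going by the values given here, no measured compound carries chlorine, and none carries a 2-chlorophenyl group, so the guess stays loose. A drop of modest to large size, beyond the scatter, is the likely outcome. The expected step is an 11-fold lower number from compound 3 to compound 4 (1.03 log units; beyond the scatter) on this reasoning. For compound 4 the estimated value is 1500 nM with an expected range of 300 nM to 7000 nM around it.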

Compound 4, half-maximal inhibitory concentration: 4200 nM
For compound 4 the middle estimate is 2.8-fold (0.45 log units) below the measured one; measured number inside the range.
By their numbers in this assay, from the lowest: compound 2; then compounds 1 and 4 (each within the scatter of the next); then compound 3.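

In this assay, 2-chlorophenyl in place of 4-methylphenyl gives a 3.8-fold lower number from compound 3 to compound 4 (0.58 log units; beyond the scatter) and so places a third halogen-bearing compound below the methyl compound, although this single swap changes both the group on the ring and its printed ring position, 2 rather than 4. Among the halogen-bearing compounds, 2-chlorophenyl in place of 4-bromophenyl gives a 17-fold higher number from compound 2 to compound 4 (1.23 log units; beyond the scatter) while 2-chlorophenyl in place of 4-fluorophenyl gives a 1.7-fold higher number from compound 1 to compound 4 (0.23 log units; within the scatter) and therefore leaves those two compounds level, showing that a halogen on this ring does not by itself reach the low number of compound 2. Nothing measured on these compounds accounts for these differences.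

A 4-chlorophenyl or a 2-methylphenyl group at the same place would help separate the effect of the atom from that of its ring position. Going by these compounds, how the activity would respond to groups of a different kind on this ring, such as a methoxy group, an amine or a carboxylic acid, also remains open.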